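This account rests on a few compounds, and the source may have more. Where it says the series, first, only, none or still open, it means among the compounds named here.

Series notes. Among the compounds with values here, in an ADME assay on MRC5 cells (Homo sapiens) for inhibition, with a stated time of 72 h (a higher number here means that more compound is needed for the effect, a lower number that less compound is needed), compound 3 `COc1cccc(OC)c1C(=O)Nc1c[nH]nc1C(=O)N[C@H]1CC[C@H](O)CC1` gives 34000 nM, the highest number of the three measured so far; compound 1 `CO[C@H]1CC[C@H](NC(=O)c2n[nH]cc2NC(=O)c2cnc3ccccn23)CC1` gives 5900 nM and compound 2 `COc1ccccc1C(=O)Nc1c[nH]nc1C(=O)N[C@H]1CC[C@H](OC)CC1` gives 1500 nM. Within the data shown here, the only single-point step in hand, a 3.9-fold lower number from compound 1 to compound 2 (0.59 log units; beyond the scatter), sits on the carbonyl carbon and leaves the amide nitrogen untouched. Compound 4 `COc1cccc(OC)c1C(=O)Nc1c[nH]nc1C(=O)NC1CCC1` differs from compound 3 by cyclobutyl in place of 4-hydroxycyclohexyl on an amide-type nitrogen. Among the measured compounds shown here, no measured step alters the group on that nitrogen, so the numbers fix neither size nor direction; compounds 2 and 3 differ in two places at once, and their two values cannot be separated. For compound 4 the step of a 1.7-fold lower number from compound 3 to compound 4 (0.23 log units; within the scatter) is expected to stay small, with wide uncertainty. In this assay compound 4 is estimated at 20000 nM, within 4000 nM to 100000 nM.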

Compound 4, half-maximal effective concentration: > 50000 nM
Compound 4 ended at the assay's limit; the forecaster's own chance of this, stated with the estimate: 25%; middle value at least 2.5-fold (0.39 log units) away from the limit.
By their numbers in this assay, from the lowest: compound 2; then compound 1; then compound 3. At a limit, above all of these: compound 4.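

The amide nitrogen now has a readable step: in this assay, cyclobutyl in place of 4-hydroxycyclohexyl gives an at least 1.4-fold higher number from compound 3 to compound 4 (0.16 log units; that floor lies within the scatter). Compound 4 stands at a limit of the assay, not at a number: the limit of > 50000 nM in this assay, at which 1 of the 4 values shown sits. This change on the nitrogen therefore brings no lower number, though the size of the step stays unfixed.

Ring size and the loss of the hydroxy group change together here, so their shares cannot be told apart. Unsubstituted cyclohexyl on that nitrogen would be the group to separate them, and 4-aminocyclohexyl would test another substituent on the ring.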